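The compounds below may be only part of what the source reports. "The series", "measured", "known", "first", "only" and "open" are said of these compounds alone.

Measured so far:
- compound 1, `CC(C)C[C@@H]1C(=O)N[C@H](C2Cc3ccccc3C2)C(=O)N1[C@@H](C(=O)NC(C)C)c1ccco1`, 6.31 nM
- compound 2, `Cc1cc([C@H](C(=O)NC(C)C)N2C(=O)[C@@H](C3Cc4ccccc4C3)NC(=O)[C@H]2CC(C)C)oc1C`, 1.26 nM

Both compounds were tested in an assay on isolated protein for binding affinity to Oxytocin receptor (Homo sapiens); a higher number here means a weaker inhibitor, a lower number a stronger inhibitor. Compound 2 has the lowest number of the two, and its nearest neighbour, compound 1, stands apart from it by a gap that is beyond the usual scatter: a 5.0-fold lower number from compound 1 to compound 2 (0.70 log units; beyond the scatter). That step came from a 4,5-dimethylfuran-2-yl in place of a furan-2-yl on a saturated chain carbon bound to an amide-type nitrogen in a ring and a carbonyl carbon.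

Compound 3, `CNC(=O)c1ccc([C@H](C(=O)NC(C)C)N2C(=O)[C@@H](C3Cc4ccccc4C3)NC(=O)[C@H]2CC(C)C)o1`, is not yet measured. It differs from compound 2 at the same place: a group of 9 heavy atoms (6 carbon, 1 nitrogen, 2 oxygen; one five-membered aromatic ring with 1 hetero atom) in place of a group of 7 heavy atoms (6 carbon, 1 oxygen; one five-membered aromatic ring with 1 hetero atom), on a saturated chain carbon bound to an amide-type nitrogen in a ring and a carbonyl carbon. Among the compounds with values here, the only measured step at this position is a 5.0-fold lower number from compound 1 to compound 2 (0.70 log units; beyond the scatter), which shows that the furan substituents matter here, but it does not tell how a methylcarbamoyl group will compare with two methyl groups. The change is therefore expected to give a step of a 2.0-fold higher number from compound 2 to compound 3 (0.30 log units; within the scatter), most likely within the scatter or a modest loss. Compound 3 is estimated at 2.5 nM, with a range from 0.6 nM to 12 nM.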

Compound 3, inhibition constant: 39.8 nM
Compound 3: middle estimate off by 16-fold (1.20 log units), on the low side, outside the stated range (above it).
By their numbers in this assay, from the lowest: compound 2; then compound 1; then compound 3.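

In this assay the furan ring does not answer to substitution in one direction only: a 5.0-fold lower number from compound 1 to compound 2 (0.70 log units; beyond the scatter) came with 4,5-dimethylfuran-2-yl in place of furan-2-yl, whereas methylcarbamoyl in place of hydrogen on an aromatic carbon gives a 6.3-fold higher number from compound 1 to compound 3 (0.80 log units; beyond the scatter) and so moves the number the opposite way. The comparison between the two substituted furans shows how sharply this position can tell groups apart, with a 32-fold higher number from compound 2 to compound 3 (1.50 log units; beyond the scatter) as the large step on going from 4,5-dimethylfuran-2-yl to the methylcarbamoyl-bearing group, which has 1 hydrogen-bond donor and 2 hydrogen-bond acceptors against 0 and 1. Nothing available here gives a measured reason for this reversal.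

The compounds shown leave open whether the loss follows the whole methylcarbamoyl group or only its amide hydrogen, a question that a dimethylcarbamoyl group on the same furan would help to separate. They also leave open whether a single methyl group on the furan would be enough to give the improvement seen with the two methyl groups of compound 2.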